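A Second Chloro on the Core of Compound 2

The compounds below may be only part of what the source reports. "The series", "measured", "known", "first", "only" and "open" are said of these compounds alone.

Three compounds have been tested in a functional assay on SF-295 cells (Homo sapiens) for cytotoxicity, read by sulforhodamine B assay, with a stated time of 48 h; on this read-out lower numbers stand for higher toxicity in this test and higher numbers for lower toxicity in this test:

compound 1 `ClCc1ccccc1Cn1cnc2c(Cl)ncnc21`: 51300 nM
compound 2 `ClCc1cccc(Cn2cnc3ncnc(Cl)c32)c1`: 64600 nM
compound 3 `ClCc1cccc(Cn2cnc3c(Cl)ncnc32)c1`: 29500 nM

Of these three numbers, compound 2 holds the highest. Its nearest neighbour is compound 1, whose value sits within the usual scatter of the reading for compound 2, so the two cannot be told apart. Compound 3 lies furthest away, with a number that stands beyond the scatter below that of compound 2, so on this read-out compound 3 is the more toxic of that pair.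

Compound 4 `ClCc1cccc(Cn2cnc3nc(Cl)nc(Cl)c32)c1` has not been measured. It differs from compound 2 in one place: chloro in place of hydrogen on an aromatic carbon, the new group sitting between two ring nitrogen atoms and meta to a chloro group.

For the measured compounds named here, no measured pair shows what such a change does on this core, so the expectation for compound 4 rests only on the spread of the three known values, which all lie close together. Compound 4 is therefore expected to give 40000 nM in this assay, with a plausible range from 15000 nM to 100000 nM. The implied step a 1.6-fold lower number from compound 2 to compound 4 (0.21 log units; within the scatter) is expected to stay within the scatter, with no clear direction.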

Compound 4, concentration lethal to 50% of the cells: 6300 nM
The estimate for compound 4 lay 6.3-fold (0.80 log units) above the measured number, outside the stated range (below it).
By their numbers in this assay, from the lowest: compound 4; then compounds 3, 1 and 2 (each within the scatter of the next, the first and the last beyond it).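

In this assay, chloro in place of hydrogen on the aromatic carbon between two ring nitrogen atoms gives a 10-fold lower number from compound 2 to compound 4 (1.01 log units; beyond the scatter) and so moves the reading towards higher toxicity in this test. For the compounds shown here, the earlier compounds included no pair differing in one place, so only this step shows that the position is not indifferent to substitution on the core of compound 2, and that a single added chlorine atom there can shift the number well beyond the scatter. Nothing given here accounts for a step of this size.

As far as these compounds go, what remains open is whether this step belongs to chloro itself or would also appear with another group on the same carbon, such as an amine, a methoxy group or a fluoro group. From the compounds shown here alone, it is also open whether the same chloro in place of hydrogen would give a step of similar size on the core of compound 1 or compound 3, where the chloromethyl-bearing benzyl group or the existing chloro group is arranged differently.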